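The source may hold more compounds than are shown below. What is called first, only, known or untested is meant among the compounds shown, and "the series" means these compounds.

Measured so far in a functional assay on MCF7 cells (Homo sapiens) for inhibition, read by MTT assay, with a stated time of 72 h; a higher number here means a weaker inhibitor, a lower number a stronger inhibitor:
Compound 1 `COc1ccc(C(=O)/C=C/c2cc(OC)c(OC)cc2OC)cc1` gives 33900 nM
Compound 2 `COc1cc(OC)c(OC)cc1/C=C/C(=O)c1ccc(C)cc1` gives 33000 nM
Compound 3 `COc1cc(OC)c(C2CC(=O)c3cc(O)ccc3O2)cc1OC` gives > 150000 nM as a limit of the assay

Among the compounds with values here, compound 2 stands level with its one numerical neighbour, as the step of a 1.0-fold lower number from compound 1 to compound 2 (0.01 log units; within the scatter) shows. Within the data shown here, the value of compound 3 is a limit and yields no step.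

Next is compound 4 `COc1cc(OC)c(OC)cc1/C=C/C(=O)c1ccc(Br)cc1` which differs from compound 2 by bromo in place of methyl on an aromatic carbon and so carries bromo in place of methyl on an aromatic carbon, para to a large group. Among the measured compounds shown here, no bromo compound has been measured yet in this assay so the evidence is indirect. For the measured compounds named here, one measured step bears on this place, methyl in place of methoxy on an aromatic carbon. That step, a 1.0-fold lower number from compound 1 to compound 2 (0.01 log units; within the scatter) is the basis for expecting little movement from compound 2 here. The expected step is a 1.2-fold lower number from compound 2 to compound 4 (0.07 log units; within the scatter) and no change beyond the scatter is expected. Compound 4 is estimated at 28000 nM with an expected range of 12000 nM to 65000 nM in this series.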

Compound 4, half-maximal inhibitory concentration: 18300 nM
Estimate against measurement, compound 4: 1.5-fold (0.18 log units) above; measured number inside the range.
By their numbers in this assay, from the lowest: compounds 4, 2 and 1 (each within the scatter of the next). At a limit, above all of these: compound 3.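

In this assay, the aromatic carbon para to a large group now carries a third kind of group, and the bromo compound separates from neither neighbour: a 1.8-fold lower number from compound 2 to compound 4 (0.26 log units; within the scatter), and a 1.9-fold lower number from compound 1 to compound 4 (0.27 log units; within the scatter). Methoxy, methyl and bromo at this place therefore cannot be told apart in this assay, which extends the earlier reading from two groups to three, the first of them a halogen. Nothing on hand accounts for this result.

From the compounds shown here alone, whether an amine, a carboxylic acid or a trifluoromethyl group at the same carbon would move the number beyond the scatter remains open. Also open, going by these compounds, is whether fluoro or chloro would stay level with bromo here.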